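From ethoxycarbonyl to ethyl on the nitrogen

The source may report more compounds than this note shows. Statements on the series, on what has been measured and on what is new or still open speak of the compounds shown alone.

Measured so far in a functional assay on the whole organism with Mus musculus as the target (on this read-out higher numbers stand for an effect only at larger amounts of compound and lower numbers for an effect already at smaller amounts), are these compounds:
- compound 1 `Cc1c(C)c2c(c(C)c1N)CC(C)(C)O2` with 7.8 mg/kg as a number
- compound 2 `Cc1c(C)c2c(c(C)c1NC=O)CC(C)(C)O2` with > 100 mg/kg as a limit
- compound 3 `CCOC(=O)Nc1c(C)c(C)c2c(c1C)CC(C)(C)O2` with > 100 mg/kg as a limit

Compound 3 stands at the limit of > 100 mg/kg in this assay, at which 2 of the 3 values shown sit, and so has no number of its own. The change to compound 4 `CCNc1c(C)c(C)c2c(c1C)CC(C)(C)O2` puts ethyl in place of ethoxycarbonyl on a nitrogen on an aromatic ring and removes the carbonyl from that nitrogen. Going by the values given here, two measured steps bear on this. Ethoxycarbonyl in place of hydrogen gave an at least 12-fold higher number from compound 1 to compound 3 (1.10 log units; beyond the scatter) and formyl in place of hydrogen gave an at least 12-fold higher number from compound 1 to compound 2 (1.10 log units; beyond the scatter) in the same place. Among the compounds with values here, both steps start from compound 1 at 7.8 mg/kg as the one measured number. Within the data shown here, no measured compound carries ethyl on that nitrogen, so the reversal may be only partial. Still, a large step to a lower number in this assay is expected, namely an at least 6.6-fold lower number from compound 3 to compound 4 (0.82 log units; beyond the scatter) as the estimate. The estimate for compound 4 is 15 mg/kg with an expected range from 4 mg/kg to 60 mg/kg as its span.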

Compound 4, dose for 50% inhibition: 38.9 mg/kg
For compound 4 the middle estimate is 2.6-fold (0.41 log units) below the measured one, and the stated range covers the measured number.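

In this assay, a group on the nitrogen on an aromatic ring does not by itself put a compound at the limit: ethyl in place of ethoxycarbonyl gives an at least 2.5-fold lower number from compound 3 to compound 4 (0.41 log units; beyond the scatter), and ethyl in place of formyl gives an at least 2.5-fold lower number from compound 2 to compound 4 (0.41 log units; beyond the scatter). Even so, the free amine is not matched, for ethyl in place of hydrogen gives a 5.0-fold higher number from compound 1 to compound 4 (0.70 log units; beyond the scatter), so the loss of the carbonyl recovers only part of what these groups on that nitrogen cost. Compound 2 and compound 3 each stand at a limit and not at a number, and the two steps to compound 4 are lower bounds because of this: the limit of > 100 mg/kg in this assay, at which 2 of the 4 values shown sit.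

How far the number moves with the size of the group on that nitrogen stays open, as the compounds shown hold only ethyl there without a carbonyl. A methyl, a longer chain such as butyl, or a second ethyl on the same nitrogen could settle this.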